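The compounds below may be only part of what the source reports. "The series", "measured", "known", "first", "only" and "open" are said of these compounds alone.

Measured compounds:
- compound 1 `COc1ccc(-c2c(O)nc3cc(Cl)c([N+](=O)[O-])cc3c2OCCC2CCCCN2)cc1OC`: 600 nM
- compound 2 `Cc1cc(C)cc(-c2c(O)nc3cc(Cl)c(NC(=O)Nc4cccnc4)cc3c2OCCC2CCCCN2)c1`: 20 nM
- compound 3 `Cc1cc(C)cc(-c2c(O)nc3cc(Cl)c(NC(=O)Nc4ncccn4)cc3c2OCCC2CCCCN2)c1`: 6 nM

In a functional assay on cells (Pituitary gland cell) for antagonist activity at Gonadotropin-releasing hormone receptor (Rattus norvegicus) (on this read-out higher numbers stand for weaker inhibition and lower numbers for stronger inhibition), compound 1 gives the highest of the three numbers: compound 2 lies a good deal lower, and compound 3 lower still. Within the data shown here, the one single-place step known in the set is a 3.3-fold lower number from compound 2 to compound 3 (0.52 log units; beyond the scatter); it concerns the urea-linked ring of the shared core and leaves the aryl group at the hydroxy-bearing ring untouched.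

The next compound, compound 4 `O=[N+]([O-])c1cc2c(OCCC3CCCCN3)c(-c3ccccc3Cl)c(O)nc2cc1Cl`, differs from compound 1 only at that aryl group: 2-chlorophenyl in place of 3,4-dimethoxyphenyl on an aromatic carbon. Among the measured compounds shown here, no measured pair isolates this change. Compounds 2 and 3 carry a different aryl group there, but they also differ from compound 1 at the urea position, so their values show only that the combination of both changes gives much lower numbers; they say nothing on their own about the aryl swap. The nitro-bearing core of compound 1 is kept in compound 4, so the comparison rests on compound 1 alone.

For the measured compounds named here, with no step bearing on the change, the expectation for compound 4 in this assay is held close to compound 1, with a wide range in either direction: an estimated 700 nM (150 nM to 3500 nM), i.e. an expected 1.2-fold higher number from compound 1 to compound 4 (0.07 log units; within the scatter).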

Compound 4, half-maximal inhibitory concentration: 360 nM
Compound 4: the middle estimate sits 1.9-fold (0.29 log units) above what was measured; low and high end bracket the measured number.
By their numbers in this assay, from the lowest: compound 3; then compound 2; then compounds 4 and 1 (each within the scatter of the next).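

In this assay, among these compounds, the one readable step at this aryl position is a 1.7-fold lower number from compound 1 to compound 4 (0.22 log units; within the scatter), which stays within the scatter, for 2-chlorophenyl in place of 3,4-dimethoxyphenyl on the aromatic carbon ortho to the 2-(piperidin-2-yl)ethoxy group and ortho to the hydroxy group. On the nitro-bearing core, this read-out therefore does not separate an aryl group carrying hydrogen-bond acceptors and more heavy atoms from one carrying chlorine and no hydrogen-bond acceptors, so this swap alone gives nothing like the much lower numbers of compounds 2 and 3. Nothing on hand explains why the two aryl groups fall so close together.

The compounds shown leave open how much of the lower numbers of compounds 2 and 3 comes from the urea position and how much from their aryl group, and whether a urea-bearing compound with 2-chlorophenyl would hold those numbers. They also leave open whether this position stays as flat with an unsubstituted phenyl, a 4-chlorophenyl or a pyridyl ring, and what an amine in place of the nitro group would give with either aryl group.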